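Thiazolylacetamide triazoles: pyridyl for chlorophenyl

A few compounds are considered here, and "the series" means these few. Any claim that something is new, unique, unknown or untested is made for them only; others in the source may bear on it.

Working notes on a short series of triazolylacetamides carrying a thiazol-2-yl amide. Two compounds carry measured values in a functional assay on BMDM cells (Mus musculus, strain C57BL/6) for inhibition, with a stated time of 2 days; on this read-out higher numbers stand for weaker inhibition and lower numbers for stronger inhibition. Compound 1 `O=C(Cn1cc(-c2ccncc2)nn1)Nc1nccs1` gives 2 nM in this assay. Compound 2 `Cc1csc(NC(=O)Cn2cc(-c3ccc(Cl)cc3)nn2)n1` gives 520 nM in this assay, the highest of the two numbers shown; its nearest neighbour is compound 1, a difference that is well beyond the scatter of repeated measurements.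

The pair considered here is compound 2 to compound 3 `Cc1csc(NC(=O)Cn2cc(-c3ccncc3)nn2)n1`, the latter not yet measured. The change is pyridin-4-yl in place of 4-chlorophenyl on an aromatic carbon.

Within the data shown here, no step between two measured compounds shares this change, so its size is not known from the data. Compound 3 also shares its pyridin-4-yl group with compound 1, whose value of 2 nM is the low end of the series. On that basis a large drop, toward stronger inhibition, is expected for the step of a 65-fold lower number from compound 2 to compound 3 (1.81 log units; beyond the scatter) in this assay. Compound 3 is therefore estimated at 8 nM in this assay, with a range from 2 nM to 40 nM.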

Compound 3, half-maximal inhibitory concentration: 100 nM
The estimate for compound 3 lay 13-fold (1.10 log units) below the measured number, outside the stated range (above it).
By their numbers in this assay, from the lowest: compound 1; then compound 3; then compound 2.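

In this assay pyridin-4-yl in place of 4-chlorophenyl, on an aromatic carbon of the five-membered aromatic ring with 3 nitrogen, gives a 5.2-fold lower number from compound 2 to compound 3 (0.72 log units; beyond the scatter) and so a modest gain in inhibition that lies beyond the scatter. Pyridin-4-yl alone does not carry the methyl-bearing compounds to the level of compound 1: methyl in place of hydrogen on an aromatic carbon gives a 50-fold higher number from compound 1 to compound 3 (1.70 log units; beyond the scatter) in the same read-out, a large loss, and this single change outweighs the modest gain of the aryl exchange. No measured property accompanies either step, so neither can be tied to a cause.

From the compounds shown here alone, the size of the aryl exchange is known only with the methyl present, so it remains open whether pyridin-4-yl in place of 4-chlorophenyl gives a step of similar size in the compounds carrying hydrogen at that carbon. Also open, going by these compounds, is how far the loss depends on the methyl itself, as ethyl or a fluorine atom at that carbon, or pyridin-3-yl in place of pyridin-4-yl, would show.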